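The compounds below may be only part of what the source reports. "The series", "measured", "known", "first", "only" and "open" are said of these compounds alone.

Compound 1 `COc1cc(Nc2nc3ccccc3nc2S(=O)(=O)c2ccccc2)cc(OC)c1` is the most potent of the three measured compounds. In a functional assay on A549 cells (Homo sapiens) for cytotoxicity, read by MTT assay, with a stated time of 72 h (a higher number here means a weaker inhibitor, a lower number a stronger inhibitor), compound 1 gives 70 nM. Two compounds each differ from it in one place. Compound 2 `Nc1ccc(Nc2nc3ccccc3nc2S(=O)(=O)c2ccccc2)cc1` carries the change 4-aminophenyl in place of 3,5-dimethoxyphenyl on a nitrogen on an aromatic ring and in this assay compound 2 gives 12900 nM, a step of a 180-fold higher number from compound 1 to compound 2 (2.27 log units; beyond the scatter). Compound 3 `COc1cc(Nc2nc3ccccc3nc2S(=O)(=O)c2ccc(Br)cc2)cc(OC)c1` differs from compound 1 by bromo in place of hydrogen on an aromatic carbon, and in this assay compound 3 gives 15900 nM, a step of a 230-fold higher number from compound 1 to compound 3 (2.36 log units; beyond the scatter). The values of compound 2 and compound 3 lie within the scatter of each other, so no order between them can be read.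

Compound 4 `Nc1ccc(Nc2nc3ccccc3nc2S(=O)(=O)c2ccc(Br)cc2)cc1` has not yet been measured. It differs from compound 3 by 4-aminophenyl in place of 3,5-dimethoxyphenyl on a nitrogen on an aromatic ring, the same change as from compound 1 to compound 2, at the same place. On the core of compound 1 that change made the large step of a 180-fold higher number from compound 1 to compound 2 (2.27 log units; beyond the scatter). For compound 3 to compound 4 a smaller step is expected than the earlier one, because compound 3 already gives a number far above compound 1 after the step of a 230-fold higher number from compound 1 to compound 3 (2.36 log units; beyond the scatter), and a cell assay of this kind may report only a limit for very weak compounds. The expected step is a 3.1-fold higher number from compound 3 to compound 4 (0.50 log units; beyond the scatter). Compound 4 is estimated at 50000 nM, within 15000 nM to 200000 nM.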

Compound 4, half-maximal inhibitory concentration: 1020 nM
Estimate against measurement, compound 4: 49-fold (1.69 log units) above, and the stated range ends above it.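

In this assay, the change from 3,5-dimethoxyphenyl to 4-aminophenyl does not carry over from one core to the other; where the bromo is present it runs the opposite way, a 16-fold lower number from compound 3 to compound 4 (1.19 log units; beyond the scatter), and the two steps disagree far beyond what scatter could explain: the same change on two cores in this assay, a 180-fold higher number (2.27 log units; beyond the scatter) from compound 1 to compound 2 and a 16-fold lower number (1.19 log units; beyond the scatter) from compound 3 to compound 4, 2900-fold (3.46 log units) apart, beyond the scatter of two such steps. Read the other way round, the bromo change also reverses, giving a 13-fold lower number from compound 2 to compound 4 (1.10 log units; beyond the scatter) when the 4-aminophenyl is present, in contrast to the large rise it gave on compound 1: the same change on two cores in this assay, a 230-fold higher number (2.36 log units; beyond the scatter) from compound 1 to compound 3 and a 13-fold lower number (1.10 log units; beyond the scatter) from compound 2 to compound 4, 2900-fold (3.46 log units) apart, beyond the scatter of two such steps. So in these four compounds the effect of each change depends on the other, and a step measured on one core could not be used to predict the step on the other, but a single set of four compounds does not show why this happens or whether it holds for other groups.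

On these data alone, it remains open whether chloro or methyl in place of the bromo would give the same reversal. As far as these compounds go, it is equally open whether a phenyl carrying a hydroxyl or a single methoxy in place of the 4-aminophenyl would do so.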